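A few compounds are considered here, and "the series" means these few. Any claim that something is new, unique, unknown or untested is made for them only; others in the source may bear on it.

Series notes. Compound 1 `O=C(CCCCCCN1C(=O)/C(=N\O)c2ccccc21)NO` gives 640 nM in a functional assay on SW-620 cells (Homo sapiens) for antiproliferative activity, read by sulforhodamine B assay, with a stated time of 48 h; a higher number here means a weaker inhibitor, a lower number a stronger inhibitor. Compound 2 `O=C(CCCCCCN1C(=O)/C(=N\O)c2cc(F)ccc21)NO` gives 110 nM in this assay; the change is fluoro in place of hydrogen on an aromatic carbon and the step is a 5.8-fold lower number from compound 1 to compound 2 (0.76 log units; beyond the scatter). Compound 3 `CO/N=C1/C(=O)N(CCCCCCC(=O)NO)c2ccccc21` carries a different core; how the two cores differ is not broken down here. In this assay compound 3 gives 730 nM, which is within the scatter of compound 1 and well apart from compound 2. Compound 4 `CO/N=C1/C(=O)N(CCCCCCC(=O)NO)c2ccc(F)cc21` is not yet measured; it differs from compound 3 by fluoro in place of hydrogen on an aromatic carbon, the same change as that from compound 1 to compound 2, at the same place. Because a 5.8-fold lower number from compound 1 to compound 2 (0.76 log units; beyond the scatter) was measured on a closely related core, a step of similar size is expected, estimated as a 4.9-fold lower number from compound 3 to compound 4 (0.69 log units; beyond the scatter), though a single precedent gives only modest confidence. Compound 4 is therefore estimated at 150 nM, with a likely range of 60 nM to 400 nM.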

Compound 4, half-maximal inhibitory concentration: 1110 nM
Beside the measured number, compound 4's estimate is 7.4-fold (0.87 log units) below it; measured number outside the range, above it.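

Fluoro in place of hydrogen on an aromatic carbon does not carry over from one core to the other in this assay: the same change on two cores in this assay, a 5.8-fold lower number (0.76 log units; beyond the scatter) from compound 1 to compound 2 and a 1.5-fold higher number (0.18 log units; within the scatter) from compound 3 to compound 4, 8.8-fold (0.95 log units) apart, beyond the scatter of two such steps. On the core of compound 3 the change gives a 1.5-fold higher number from compound 3 to compound 4 (0.18 log units; within the scatter), so the drop seen on the core of compound 1 cannot be assumed for a related core. This rests on a single pair per core and a single place on the ring, and it does not show what causes the difference or how any other group would behave.

Open, from the compounds shown here alone, is whether chloro or methoxy at the same place would also differ between the two cores. Also open, going by these compounds, is whether a longer chain leading to the hydroxamic acid would alter the outcome on either core.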